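Swapping an Ester for a Nitrile on the Same Core

The source may hold more compounds than are shown below. What is called first, only, known or untested is meant among the compounds shown, and "the series" means these compounds.

Three compounds share one core. Compound 1 `CCC1(Cc2ccccc2)OS(=O)(=O)C=C1OCCCCc1ccccc1` carries a 3-phenylpropyl group on the saturated chain carbon bound to an oxygen on an unsaturated carbon; in an ADME assay on HEL cells (Homo sapiens) for cytotoxicity, with a stated time of 3 days (a higher number here means that more compound is tolerated, a lower number that less compound is tolerated), compound 1 gives 99000 nM. Compound 2 `CCC1(Cc2ccccc2)OS(=O)(=O)C=C1OCC(=O)OC` carries a methoxycarbonyl group in that place. In this assay compound 2 gives > 200000 nM, which is a limit of the assay rather than a number (the limit of > 200000 nM in this assay, at which 1 of the 2 values shown sits). The measured step of an at least 2.0-fold higher number from compound 1 to compound 2 (0.30 log units; that floor lies within the scatter) therefore gives only a floor, not a size. Compound 3 `CCC1(Cc2ccccc2)OS(=O)(=O)C=C1OCC#N` has not been measured; it differs from compound 2 by cyano in place of methoxycarbonyl on a saturated chain carbon bound to an oxygen on an unsaturated carbon. Going by the values given here, only one measured step bears on this change, and it is itself a limit, so the expectation rests on little. The step of a number no higher from compound 2 to compound 3 (the limit leaves the size open) is expected to stay within the scatter. There is a good chance that compound 3 also reaches the limit. Compound 3 is therefore estimated at 200000 nM, within 80000 nM to 500000 nM.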

Compound 3, half-maximal cytotoxic concentration: > 200000 nM
Compound 3 was reported as a limit (the forecaster's own chance of this, stated with the estimate: 60%); the middle value lies on the limit itself.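

In this assay compound 3 gives > 200000 nM, which is a limit of the assay and not a number. Putting cyano in place of 3-phenylpropyl gives an at least 2.0-fold higher number from compound 1 to compound 3 (0.30 log units; that floor lies within the scatter), so this is a second floor at this position rather than a measured size. The step from compound 2 to compound 3 cannot be read, so the swap of methoxycarbonyl for cyano has no size that can be stated, and the two compounds share the same ceiling: the limit of > 200000 nM in this assay, at which 2 of the 3 values shown sit.

Going by these compounds, whether cyano and methoxycarbonyl differ at all therefore stays open, since neither compound has a true number in this assay. Also open, on these data alone, is whether an amine, a carboxylic acid or a longer chain at this place would stay at the limit or give a readable number, as compound 1 does.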